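A few compounds are considered here, and "the series" means these few. Any claim that something is new, unique, unknown or untested is made for them only; others in the source may bear on it.

Measured so far, in a functional assay on the whole organism (spleen, spleen) with Rattus norvegicus as the target; a higher number here means that more compound is needed for the effect, a lower number that less compound is needed:
Compound 1, `C=CCC(N)(CO)CCc1ccc(OCCCCCCC)cc1`, gives 1.9 mg/kg.
Compound 2, `CCCCCCCOc1ccc(CCC(N)(CO)CCC)cc1`, gives 3.1 mg/kg.

Among the compounds with values here, compound 2 carries the higher of the two numbers, but its only neighbour is compound 1, and the difference between them, a 1.6-fold higher number from compound 1 to compound 2 (0.21 log units; within the scatter), is no larger than repeated measurements of the same compound commonly show. On these numbers compound 2 therefore stands level with compound 1 rather than apart from it.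

Compound 3, `CCCCCCCOc1ccc(CCC(N)(CO)CCCC)cc1`, is compound 2 with one small change: methyl in place of hydrogen on a saturated chain carbon, four bonds along the chain from an amine nitrogen. Within the data shown here, the only measured step that speaks to this region of the molecule is the one from compound 1 to compound 2, which also altered the chain on that carbon and moved the number by only a 1.6-fold higher number from compound 1 to compound 2 (0.21 log units; within the scatter), within the scatter. Lengthening that same chain by one carbon is a smaller alteration than swapping vinyl for ethyl, so no step beyond the scatter is expected in this assay, in either direction.

Compound 3 is therefore expected to give about 3 mg/kg, most likely between 1.5 mg/kg and 6 mg/kg, an expected step of a 1.0-fold lower number from compound 2 to compound 3 (0.01 log units; within the scatter) from compound 2.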

Compound 3, dose for 50% inhibition: > 10 mg/kg
Compound 3: no number, only a limit (the forecaster's own chance of this, stated with the estimate: 5%); at least 3.3-fold (0.52 log units) between middle value and limit.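

In this assay compound 3 gives > 10 mg/kg, which is a limit of the assay and not a number: the limit of > 10 mg/kg in this assay, at which 1 of the 3 values shown sits.

Methyl in place of hydrogen on a saturated chain carbon, four bonds along the chain from an amine nitrogen, brings an at least 3.2-fold higher number from compound 2 to compound 3 (0.50 log units; beyond the scatter), and the change in the same chain counted against the vinyl compound, propyl in place of vinyl, brings an at least 5.2-fold higher number from compound 1 to compound 3 (0.72 log units; beyond the scatter). From the compounds shown here alone, the first two compounds could not show this: they suggested that this chain might be changed freely, whereas a single added methyl now requires clearly more compound for the effect, so the chain's length matters in this assay, and the full size of the step remains unknown.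

The compounds shown do not say how much higher the number for compound 3 really lies, or whether a still longer chain would behave the same way. They also leave open how a shorter methyl group on this carbon, or a chain of this length ending in a hydroxyl group, would fare, and they give no reason for the step seen here.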